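A Chlorine Moved Around the Phenyl Ring

The source may report more compounds than this note shows. Statements on the series, on what has been measured and on what is new or still open speak of the compounds shown alone.

Compound 1, `Cc1nc2cc(OC[C@H](O)CN3CCN(Cc4noc(-c5ccc(Cl)cc5)n4)CC3)ccc2s1`, was tested in a functional assay on mitochondria from heart for inhibition of peroxisomal acyl-coenzyme A oxidase 1 (Rattus norvegicus) (a higher number here means a weaker inhibitor, a lower number a stronger inhibitor), where compound 1 gives 2270 nM. Among the three measured compounds, compound 1 sits second highest of the three numbers. Its nearest neighbour is compound 3, `Cc1nc2cc(OC[C@H](O)CN3CCN(Cc4nc(-c5ccc(C(F)(F)F)cc5)sc4C)CC3)ccc2s1`, which in this assay gives 1500 nM, a difference that lies within the usual scatter of repeated measurements. Furthest away is compound 2, `Cc1nc2cc(OC[C@H](O)CN3CCN(Cc4nnc(-c5ccc(Cl)cc5)o4)CC3)ccc2s1`, which in this assay gives 8500 nM, a gap beyond the scatter.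

Compound 4, `Cc1nc2cc(OC[C@H](O)CN3CCN(Cc4noc(-c5cccc(Cl)c5)n4)CC3)ccc2s1`, is built from compound 1 by a single rearrangement: 3-chlorophenyl in place of 4-chlorophenyl on an aromatic carbon. In words, 3-chlorophenyl takes the place of 4-chlorophenyl on an aromatic carbon. Among the measured compounds shown here, no measured pair in this set shows this kind of change, so there is nothing to anchor the size of the step. The step from compound 1 to compound 4 in this assay is expected to be small, a 1.3-fold higher number from compound 1 to compound 4 (0.12 log units; within the scatter), with no clear direction beyond the scatter. Compound 4 is therefore estimated to give 3000 nM in this assay, within a range from 1200 nM to 8000 nM.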

Compound 4, half-maximal inhibitory concentration: 4120 nM
Estimate against measurement, compound 4: 1.4-fold (0.14 log units) below; the range from low to high includes it.
By their numbers in this assay, from the lowest: compounds 3, 1 and 4 (each within the scatter of the next, the first and the last beyond it); then compound 2.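

In this assay, among the compounds shown here, this is the first pair that differs in one place, so it gives the first direct look at the phenyl ring: 3-chlorophenyl in place of 4-chlorophenyl gives a 1.8-fold higher number from compound 1 to compound 4 (0.26 log units; within the scatter) and the two compounds cannot be told apart. Moving the chlorine, with the same atoms joined differently, therefore has no effect here that repeated measurements could separate from scatter, though this rests on a single pair. No measurement of any property of these compounds is available to explain the step.

Going by these compounds, what remains open is whether a different group at either of these two places, such as a methoxy group, an amine or a carboxylic acid, would give a step beyond the scatter. On these data alone, it is also open whether the same chlorine move would give a similar step on the core of compound 2.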